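Nitrile for amide on a chloro-benzyloxy coumarin propanoyl chain

This account rests on a few compounds, and the source may have more. Where it says the series, first, only, none or still open, it means among the compounds named here.

Measured compounds:
compound 1 `O=C(O)c1cc(=O)oc2cc(OCc3cccc(Cl)c3)ccc12`: 100000 nM
compound 2 `O=C(O)CCc1cc(=O)oc2cc(OCc3cccc(Cl)c3)ccc12`: 1200 nM
compound 3 `NC(=O)CCc1cc(=O)oc2cc(OCc3cccc(Cl)c3)ccc12`: 15.1 nM

Three compounds share the core of compound 1 and differ only in the group carried on the aromatic carbon. In an assay on brain (strain Sprague-Dawley) for inhibition of Amine oxidase [flavin-containing] B (Rattus norvegicus), read by spectrophotometry (on this read-out lower numbers stand for stronger inhibition and higher numbers for weaker inhibition), compound 1 gives 100000 nM, compound 2 gives 1200 nM and compound 3 gives 15.1 nM. Compound 3 stands lowest of the three, with a 79-fold lower number from compound 2 to compound 3 (1.90 log units; beyond the scatter) and a 6600-fold lower number from compound 1 to compound 3 (3.82 log units; beyond the scatter), both well beyond the scatter.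

Compound 4 `N#CCCc1cc(=O)oc2cc(OCc3cccc(Cl)c3)ccc12` takes the next step from compound 3: cyano in place of carbamoyl on a saturated chain carbon, two bonds along the chain from an aromatic carbon. Going by the values given here, no measured pair shows this exact change. The step that bears most on it is a 79-fold lower number from compound 2 to compound 3 (1.90 log units; beyond the scatter), which shows that the terminal group on this chain can move this assay by a large amount; an 83-fold lower number from compound 1 to compound 2 (1.92 log units; beyond the scatter) shows the same for the chain itself. Compound 4 keeps the chain and the acceptor of compound 3 but loses its donor, so a moderate rise in the number is expected, a 4.0-fold higher number from compound 3 to compound 4 (0.60 log units; beyond the scatter), with wide uncertainty. Compound 4 is therefore estimated at 60 nM, in the range 10 nM to 400 nM.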

Compound 4, half-maximal inhibitory concentration: 28.8 nM
Beside the measured number, compound 4's estimate is 2.1-fold (0.32 log units) above it; low and high end bracket the measured number.
By their numbers in this assay, from the lowest: compounds 3 and 4 (each within the scatter of the next); then compound 2; then compound 1.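

In this assay cyano serves on this chain as well as carbamoyl, with a 1.9-fold higher number from compound 3 to compound 4 (0.28 log units; within the scatter) and thus no separation of compound 3 and compound 4. Going by these compounds alone, the low number on this chain therefore does not depend on the hydrogen-bond donor of carbamoyl, which cyano lacks, something the earlier compounds could not show, since their only change at the chain end was from carboxy to carbamoyl. The large distance from the carboxy compounds also holds with cyano, with a 42-fold lower number from compound 2 to compound 4 (1.62 log units; beyond the scatter) and a 3500-fold lower number from compound 1 to compound 4 (3.54 log units; beyond the scatter).

Nothing measured here gives a reason for this result. On these data alone, whether an amine, a methyl ester or a longer chain ending in cyano would keep the number this low remains open.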